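A few compounds are considered here, and "the series" means these few. Any claim that something is new, unique, unknown or untested is made for them only; others in the source may bear on it.

Compound 1 `Cc1ccc(N2CCN(C(=O)[C@H](C)Cc3ccc(Cl)cc3F)CC2)c([C@@H](N)CC(C)C)c1` — 20 nM
Compound 2 `COc1ccc(CC(C)C(=O)N2CCN(c3ccc(C(F)(F)F)cc3[C@@H](N)CC(C)C)CC2)cc1` — 120 nM
Compound 3 `CC(C)C[C@H](N)c1ccccc1N1CCN(C(=O)[C@H](C)Cc2ccc(Cl)cc2F)CC1` — 67 nM

All three were tested in an assay on HEK293 cells for displacement of a labelled ligand from Melanocortin receptor 4 (Homo sapiens); a lower number here means a stronger inhibitor, a higher number a weaker inhibitor. Compound 2 has the highest number of the three. Its nearest neighbour is compound 3, whose number differs from it within the usual scatter, so no order can be claimed between those two; its furthest is compound 1, and that gap is beyond the scatter, making compound 1 the stronger binder of that pair. Among the compounds with values here, the only measured step between compounds differing in a single place is a 3.4-fold higher number from compound 1 to compound 3 (0.53 log units; beyond the scatter), a modest weakening.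

The unmeasured compound 4 `CC(C)C[C@H](N)c1cc(C(F)(F)F)ccc1N1CCN(C(=O)COc2ccc([N+](=O)[O-])cc2)CC1` is derived from compound 2 by a change on the carbonyl carbon: (4-nitrophenoxy)methyl in place of 1-(4-methoxybenzyl)ethyl on a carbonyl carbon. Within the data shown here, the one measured step concerns a methyl on an aromatic carbon, not the group on the carbonyl carbon, so it offers no guidance for this swap. There is therefore no measured basis for predicting a direction, and a swap of this size could move the number either way. For compound 4 the estimate in this assay is 300 nM, with a range of 60 nM to 1500 nM. The expected step, a 2.5-fold higher number from compound 2 to compound 4 (0.40 log units; beyond the scatter), reflects this uncertainty rather than any measured trend.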

Compound 4, inhibition constant: 3100 nM
For compound 4 the middle estimate is 10-fold (1.01 log units) below the measured one; the measured number lies above the stated range.
By their numbers in this assay, from the lowest: compound 1; then compounds 3 and 2 (each within the scatter of the next); then compound 4.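

In this assay, within the data shown here, this is the first measured change to the group on the carbonyl carbon, and the cost is large: a 26-fold higher number from compound 2 to compound 4 (1.41 log units; beyond the scatter). The earlier compounds showed only what happens at a methyl on an aromatic carbon, while this result shows that the place on the carbonyl carbon does not accept every group of similar size. 1-(4-Methoxybenzyl)ethyl and (4-nitrophenoxy)methyl both have 11 heavy atoms and one six-membered aromatic ring, yet that match did not preserve binding, and nothing measured here explains the loss.

Several things differ at once in this swap, including a nitro group in place of a methoxy group and an oxygen in the chain to the ring, so the compounds shown leave open which of these accounts for the step. A (4-methoxyphenoxy)methyl group on the carbonyl carbon would separate those two features, while a 1-(4-nitrobenzyl)ethyl group would test the nitro group on the chain of compound 2.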